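The source may report more compounds than this note shows. Statements on the series, on what has been measured and on what is new or still open speak of the compounds shown alone.

Of the compounds shown here, two of this study have been measured in a functional assay on CHO-K1 cells for agonist activity at Glucose-dependent insulinotropic receptor (Mus musculus), read by HTRF and cAMP accumulation, with a stated time of 30 min; on this read-out lower numbers stand for an effect already at smaller amounts and higher numbers for an effect only at larger amounts of compound. Compound 1, `CC(C)(C)OC(=O)N1CCC(CCCNc2ccc3c(c2)NNS3(=O)=O)CC1`, gives 331 nM in this assay. Compound 2, `CCc1cnc(N2CCC(CCCNc3ccc4c(c3)OCC4=O)CC2)nc1`, gives 159 nM in this assay, the lower of the two numbers; compound 1 stands at a higher number, and the gap between the two lies beyond the usual scatter. Within the data shown here, no pair of measured compounds differs in only one place, so no measured single step is available to lean on, and the two values can only be set side by side.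

Compound 3, `CC(C)c1nnc(N2CCC(CCCNc3ccc4c(c3)OCC4=O)CC2)o1`, differs from compound 2 in one place: 5-isopropyl-1,3,4-oxadiazol-2-yl in place of 5-ethylpyrimidin-2-yl on an amine nitrogen in a ring. No comparable exchange exists among the measured compounds, so the expectation rests on compound 2 alone and is a small shift, in neither direction beyond the scatter: a 1.3-fold higher number from compound 2 to compound 3 (0.10 log units; within the scatter). Compound 3 is therefore expected to give 200 nM in this assay, with a range from 70 nM to 600 nM that allows for either a somewhat lower or a somewhat higher number.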

Compound 3, half-maximal effective concentration: 1020 nM
Estimate against measurement, compound 3: 5.1-fold (0.71 log units) below; measured number above the stated range.
By their numbers in this assay, from the lowest: compound 2; then compound 1; then compound 3.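

The ring nitrogen that carries these groups proves sensitive to the exchange: in this assay, replacing 5-ethylpyrimidin-2-yl with 5-isopropyl-1,3,4-oxadiazol-2-yl gives a 6.4-fold higher number from compound 2 to compound 3 (0.81 log units; beyond the scatter), the first single-place step available in this series. The two groups have the same number of heavy atoms, no hydrogen-bond donors and no net charge, so those shared counts do not make them interchangeable here; they differ in ring size, in their hetero atoms and hydrogen-bond acceptors, and in isopropyl against ethyl. No measured property of either group is available to account for the step.

The exchange changes the ring and the alkyl group together, so the compounds shown cannot say which part goes with the higher number; a 5-isopropylpyrimidin-2-yl or a 5-ethyl-1,3,4-oxadiazol-2-yl group on the same nitrogen would separate the two. On these data alone, it also remains open how a group without an aromatic ring, such as a simple acetyl, would read at this position on the core shared by compound 2 and compound 3.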